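The source may hold more compounds than are shown below. What is called first, only, known or untested is meant among the compounds shown, and "the series" means these compounds.

Compound 1 `N/C(=N\NC(=S)N1CCCCCC1)c1ccccn1` and compound 2 `Cc1cccc(/C(N)=N/NC(=S)N2CCCCCC2)n1` share one core and differ only by hydrogen in place of methyl on an aromatic carbon. In a functional assay on MCF7 cells (Homo sapiens) for cytotoxicity, read by MTT assay, with a stated time of 72 h, tested at 10 uM (a lower number here means less inhibition of growth, a higher number more inhibition of growth at the concentration tested), compound 2 gives 21.5%, while compound 1 gives 62.2%. Going by the values given here, that single change brought a number 40.7 percentage points higher from compound 2 to compound 1 (beyond the scatter), a large step that stands alone, with no second measured pair to confirm it. Compound 3 `Cc1cccc(/C(N)=N/NC(=S)N2CCCC2)n1` carries the same methyl but on a second core; the difference between the two cores is not broken down here. In this assay compound 3 gives 38.2%, which sits between the numbers of compound 2 and compound 1. Compound 4 `N/C(=N\NC(=S)N1CCCC1)c1ccccn1` is drawn from compound 3 by hydrogen in place of methyl on an aromatic carbon, and since the place is described in the same words as before, this is the same change seen once already. Compound 4 is therefore expected to show 68%, somewhere between 45% and 88%. For compound 4 this estimate means a step of a number 29.8 percentage points higher from compound 3 to compound 4 (beyond the scatter), expected on the strength of the earlier pair alone, so it rests on a single precedent on a different core.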

Compound 4, percent growth inhibition at one concentration: 51.7%
Beside the measured number, compound 4's estimate is 16.3 percentage points above it; measured number inside the range.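

On the second core, hydrogen in place of methyl gives a number 13.5 percentage points higher from compound 3 to compound 4 (beyond the scatter), so in this assay the change points the same way on both cores. The direction carried over from one core to the other, but the size did not: the same change on two cores in this assay, a number 40.7 percentage points higher (beyond the scatter) from compound 2 to compound 1 and a number 13.5 percentage points higher (beyond the scatter) from compound 3 to compound 4, 27.2 percentage points apart, beyond the scatter of two such steps. Two pairs do not make a rule, and they show neither that the same direction would hold on a further core nor how large a step there would be.

As far as these compounds go, all four compounds carry either methyl or hydrogen at this place, next to the ring nitrogen, so what an ethyl group, a methoxy group, an amine or a chlorine atom would do there remains open. The readings also come from a single concentration in a single cell line, which leaves open whether the difference between the two steps would hold at other concentrations or in other cells.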